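The source may hold more compounds than are shown below. What is called first, only, known or untested is meant among the compounds shown, and "the series" means these compounds.

In an assay for binding affinity to dual specificity mitogen-activated protein kinase kinase 4 (Homo sapiens), read by KINOMEscan, tested at 100 nM (a higher number here means a weaker effect of the compound at the concentration tested, a lower number a stronger effect), the measured compounds give:
compound 1 `CCCS(=O)(=O)Nc1ccc(F)c(C(=O)c2n[nH]c3ncc(-c4cccc(N)c4)cc23)c1F`: 1.6%
compound 2 `CCCS(=O)(=O)Nc1ccc(F)c(C(=O)c2n[nH]c3ncc(-c4cccc(N(C)C)c4)cc23)c1F`: 26%
compound 3 `CCCS(=O)(=O)Nc1ccc(F)c(C(=O)c2n[nH]c3ncc(-c4ccc(S(N)(=O)=O)cc4)cc23)c1F`: 0.25%

Compound 3 stands lowest of the three numbers, with compound 1 nearest, a number 1.4 percentage points lower from compound 1 to compound 3 (within the scatter), and compound 2 furthest, a number 25.8 percentage points lower from compound 2 to compound 3 (beyond the scatter). Compound 4 `CCCS(=O)(=O)Nc1ccc(F)c(C(=O)c2n[nH]c3ncc(-c4ccc(S(N)(=O)=O)cc4C)cc23)c1F` differs from compound 3 by methyl in place of hydrogen on an aromatic carbon; the sulfamoyl group and the rest of the shared core are kept. Within the data shown here, no measured step adds a methyl to an otherwise unchanged aryl group; the three steps all exchange the aryl group or its single substituent, as in a number 24.4 percentage points higher from compound 1 to compound 2 (beyond the scatter), which moved modestly. These steps therefore give no direct guide, and a change that keeps the 4-sulfamoylphenyl group is expected to leave this assay near compound 3: a number 0.8 percentage points higher from compound 3 to compound 4 (within the scatter). Compound 4 is estimated at 1%, range 0.1% to 12%.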

Compound 4, a percentage reported as activity, at one concentration (the size of the read-out at that concentration, not a potency): 3.1%
Beside the measured number, compound 4's estimate is 2.1 percentage points below it; the measured number falls inside the stated range.
By their numbers in this assay, from the lowest: compounds 3, 1 and 4 (each within the scatter of the next); then compound 2.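

Methyl on an aromatic carbon, ortho to a large group and meta to a sulfamoyl group, stays within the scatter in this assay (a number 2.9 percentage points higher from compound 3 to compound 4 (within the scatter)). The 2-methyl-4-sulfamoylphenyl group also stays within the scatter of the 3-aminophenyl group (a number 1.5 percentage points higher from compound 1 to compound 4 (within the scatter)), while the gap to the 3-(dimethylamino)phenyl group remains (a number 22.9 percentage points lower from compound 2 to compound 4 (beyond the scatter)). Nothing available explains these results. From the compounds shown here alone, whether ethyl or methoxy at this carbon would hold the read-out remains open. So does whether a carboxylic acid in place of the sulfamoyl group would do so.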